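Series notes: from compound 2 to compound 3

This account rests on a few compounds, and the source may have more. Where it says the series, first, only, none or still open, it means among the compounds named here.

Measured so far:
Compound 1 `COc1cc(NC(=O)Nc2cc(Nc3ccc(C)c(C)c3)ncn2)cc(OC)c1`: 20.1%
Compound 2 `CCc1cccc(Nc2cc(NC(=O)Nc3cc(OC)cc(OC)c3)ncn2)c1`: 27.7%

In a functional assay on NCI-H1581 cells (Homo sapiens) for inhibition, read by MTT assay, with a stated time of 48 h, tested at 10 uM (on this read-out lower numbers stand for less inhibition and higher numbers for more inhibition at the one concentration tested (going by the name of the read-out)), compound 2 has one neighbour among the measured numbers, compound 1, and the step of a number 7.6 percentage points higher from compound 1 to compound 2 (within the scatter) lies within the scatter, so the two are not separated. Compound 3 `COc1cc(NC(=O)Nc2cc(Nc3ccc(OC)c(C)c3)ncn2)cc(OC)c1` differs from compound 2 by 4-methoxy-3-methylphenyl in place of 3-ethylphenyl on a nitrogen on an aromatic ring. Among the measured compounds shown here, the only measured step, a number 7.6 percentage points higher from compound 1 to compound 2 (within the scatter), exchanged a ring on the same nitrogen and stayed within the scatter, so it is the only step that bears on this change. A step no larger than the scatter is therefore expected in this assay, estimated as a number 2.7 percentage points lower from compound 2 to compound 3 (within the scatter). Compound 3 is expected to give 25%, within 10% to 40%.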

Compound 3, a percentage reported as inhibition, at one concentration (the size of the read-out at that concentration, not a potency): 19.7%
For compound 3 the middle estimate is 5.3 percentage points above the measured one, within the range that was stated.
By their numbers in this assay, from the lowest: compounds 3, 1 and 2 (each within the scatter of the next).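

In this assay, the step of a number 8 percentage points lower from compound 2 to compound 3 (within the scatter) leaves 4-methoxy-3-methylphenyl and 3-ethylphenyl on this nitrogen unseparated. The step of a number 0.4 percentage points lower from compound 1 to compound 3 (within the scatter) shows the same for methoxy in place of methyl on an aromatic carbon, so at this position an oxygen-bearing ring is not told apart from the two carbon-only rings. No available evidence bears on these results. Still open, going by these compounds, is whether an amine or a carboxylic acid on this ring, or a chain longer than ethyl, would give a step beyond the scatter.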